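The source may hold more compounds than are shown below. What is called first, only, known or untested is meant among the compounds shown, and "the series" means these compounds.

Liver microsomes offer an early look at how quickly a compound may be cleared, and only two compounds have numbers so far. In an ADME assay on microsomes from liver (Homo sapiens) for metabolic stability, read by LC-MS, using NADPH, with a stated time of 30 min, tested at 1 uM (on this read-out higher numbers stand for fast clearance and lower numbers for slow clearance), compound 1 (`CC(C)c1noc(N2CCC(Oc3cc(N4CCc5cc(C6CCCCC6=O)ccc54)ncn3)CC2)n1`) gives 78 mL.min-1.g-1, the lower of the two numbers. Compound 2 (`CCc1cnc(N2CCC(C(C)COC(=O)N3CCc4cc(S(C)(=O)=O)cc(F)c43)CC2)nc1`) gives 329 mL.min-1.g-1, a clearly higher number, beyond the usual scatter of repeat measurements. Compound 2 differs from compound 1 in more than one place, so this gap says nothing about any single group.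

The next compound stays close to compound 1. Compound 3 (`CC(C)c1noc(N2CCC(Oc3cc(N4CCc5cc(N6CC(O)CCC6=O)ccc54)ncn3)CC2)n1`) keeps the core of compound 1 and carries 5-hydroxy-2-oxopiperidin-1-yl in place of 2-oxocyclohexyl on an aromatic carbon. Going by the values given here, no measured pair shows what this swap does in this assay, so the expectation rests on the structural change alone and the range is kept wide. A modest move toward slower clearance seems most likely, and it may stay within the scatter. The expected step is a 1.6-fold lower number from compound 1 to compound 3 (0.19 log units; within the scatter). For compound 3 the estimated value is 50 mL.min-1.g-1, with an expected range from 18 mL.min-1.g-1 to 120 mL.min-1.g-1.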

Compound 3, intrinsic clearance in microsomes: 1 mL.min-1.g-1
The estimate for compound 3 lay 50-fold (1.70 log units) above the measured number; measured number below the stated range.
By their numbers in this assay, from the lowest: compound 3; then compound 1; then compound 2.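

The swap of 2-oxocyclohexyl for 5-hydroxy-2-oxopiperidin-1-yl on this aromatic carbon gives a 78-fold lower number from compound 1 to compound 3 (1.89 log units; beyond the scatter) in this assay. Going by these compounds alone, this is the first comparison here that changes only one place, so the step belongs to this substituent, with the rest of the core of compound 1 left as it was, and it shows that the read-out can respond very strongly to a change at this position. No measurement in hand accounts for the size of this step.

The swap makes two changes at once, replacing a ring carbon with nitrogen and adding a hydroxy group, and the compounds shown cannot tell which of them carries the step, or whether it takes both. A plain 2-oxopiperidin-1-yl group would test the ring nitrogen without the hydroxy group, a hydroxy-bearing 2-oxocyclohexyl group would test the hydroxy group without the ring nitrogen, and an amine or a carboxylic acid at the same aromatic carbon would show how far the effect extends beyond these rings.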